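The source may report more compounds than this note shows. Statements on the series, on what has been measured and on what is new or still open speak of the compounds shown alone.

In a functional assay on NT2 cells (Homo sapiens) for inhibition (a higher number here means a weaker inhibitor, a lower number a stronger inhibitor), three compounds that share one core differ only in the group on a saturated chain carbon bound to a nitrogen on an aromatic ring. Compound 1 `CCC(C(=O)N[C@@H](CC(=O)O)C(=O)CSCc1ccccc1)n1ccnc(NCc2cccs2)c1=O` gives 4.56 nM, compound 2 `CCC(C(=O)N[C@@H](CC(=O)O)C(=O)CSCc1ccccc1)n1ccnc(NCC2COc3ccccc3O2)c1=O` gives 30 nM, and compound 3 `CCC(C(=O)N[C@@H](CC(=O)O)C(=O)CSCc1ccccc1)n1ccnc(NCc2cncs2)c1=O` gives 3.42 nM. Compound 3 cannot be separated from compound 1, as replacing thiophen-2-yl with 1,3-thiazol-5-yl gave a 1.3-fold lower number from compound 1 to compound 3 (0.12 log units; within the scatter). It stands clearly apart from compound 2, with an 8.8-fold lower number from compound 2 to compound 3 (0.94 log units; beyond the scatter).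

Compound 4 `CCC(C(=O)N[C@@H](CC(=O)O)C(=O)CSCc1ccccc1)n1ccnc(NCc2cc(C)no2)c1=O` is still unmeasured. It differs from compound 3 by one exchange, 3-methyl-1,2-oxazol-5-yl in place of 1,3-thiazol-5-yl on a saturated chain carbon bound to a nitrogen on an aromatic ring: 3-methyl-1,2-oxazol-5-yl in place of 1,3-thiazol-5-yl. Within the data shown here, both groups are five-membered aromatic rings, so the closest precedent is the small exchange between compound 1 and compound 3. The larger shift came with 2,3-dihydro-1,4-benzodioxin-2-yl, a different kind of group, as a 6.6-fold higher number from compound 1 to compound 2 (0.82 log units; beyond the scatter) shows. Among the measured compounds shown here, no measured compound shows what a methyl on such a ring does, which leaves the range wide, with slightly more room towards weaker inhibition. No step beyond the scatter is therefore expected, and the estimated change is a 1.5-fold higher number from compound 3 to compound 4 (0.16 log units; within the scatter). Compound 4 is expected to give about 5 nM, within an estimated range of 2 nM to 14 nM.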

Compound 4, half-maximal inhibitory concentration: 6.41 nM
Beside the measured number, compound 4's estimate is 1.3-fold (0.11 log units) below it; the measured number falls inside the stated range.
By their numbers in this assay, from the lowest: compounds 3, 1 and 4 (each within the scatter of the next); then compound 2.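

In this assay the position also accepts a five-membered aromatic ring that carries a methyl, since both a 1.9-fold higher number from compound 3 to compound 4 (0.27 log units; within the scatter) and a 1.4-fold higher number from compound 1 to compound 4 (0.15 log units; within the scatter) stay inside the usual scatter, so the thiophen-2-yl, 1,3-thiazol-5-yl and 3-methyl-1,2-oxazol-5-yl groups cannot be told apart here. The separation from the 2,3-dihydro-1,4-benzodioxin-2-yl group also holds for this new ring, with a 4.7-fold lower number from compound 2 to compound 4 (0.67 log units; beyond the scatter) and so a step beyond the scatter, which means that compound 2 remains the only one of the four set apart from the others. Nothing measured here accounts for these differences.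

Going by these compounds, the exchange from compound 3 to compound 4 alters the ring atoms and adds the methyl at once, so the share of each remains open, and a version of the ring without the methyl would be needed to separate them. On these data alone, it is also open whether this position would tolerate a carboxylic acid or an amine in place of that methyl, or a longer chain in place of the methyl, as well as it tolerates the methyl itself.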